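The source may report more compounds than this note shows. Statements on the series, on what has been measured and on what is new or still open speak of the compounds shown alone.

Measured so far in a functional assay on H184B5F5/M10 cells (Homo sapiens) for antiproliferative activity, read by XTT assay, with a stated time of 72 h; a higher number here means a weaker inhibitor, a lower number a stronger inhibitor:
compound 1 `COc1ccc(-c2cc3ccccc3nc2C=O)cc1` gives a limit, > 10000 nM.
compound 2 `COc1ccc(C(=O)/C=C/c2nc3ccccc3cc2-c2ccc(OC)cc2)cc1` gives a limit, > 10000 nM.
compound 3 `COc1ccc(-c2cc3ccccc3nc2/C=C/C(=O)c2ccc([N+](=O)[O-])cc2)cc1` gives 6100 nM.

Compound 1 stands at the limit of > 10000 nM in this assay, at which 2 of the 3 values shown sit, so only a limit and no number fixes its place among the values shown. Within the data shown here, the one step between measured compounds, an at least 1.6-fold lower number from compound 2 to compound 3 (0.21 log units; that floor lies within the scatter), changes a group on the aryl ketone end and starts from a limit, so its size is itself only a floor; it does not touch the part of compound 1 that is changed here.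

Compound 4 `COc1ccc(-c2cc3ccccc3nc2/C=C/C(=O)c2ccco2)cc1` is not yet measured; it differs from compound 1 by 2-((furan-2-yl)carbonyl)ethenyl in place of formyl on an aromatic carbon. The measured step bears on compound 4 only indirectly. Compound 2, which already carries a carbonyl-ethenyl chain on the core, gives a limit. Compound 3, which carries the same kind of chain, gives 6100 nM, a weak value. On that basis compound 4 is expected to stay in the same weak region, with a step of an at least 1.2-fold lower number from compound 1 to compound 4 (0.09 log units; that floor lies within the scatter) that stays within the scatter. The estimate for compound 4 is 8000 nM, with a range from 3000 nM to 20000 nM, and a limit rather than a number is about as likely as not.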

Compound 4, half-maximal inhibitory concentration: 6240 nM
Beside the measured number, compound 4's estimate is 1.3-fold (0.11 log units) above it; low and high end bracket the measured number.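

In this assay, 2-((furan-2-yl)carbonyl)ethenyl in place of formyl on this aromatic carbon, next to the ring nitrogen, gives an at least 1.6-fold lower number from compound 1 to compound 4 (0.20 log units; that floor lies within the scatter), and the size of that step is only a floor: the limit of > 10000 nM in this assay, at which 2 of the 4 values shown sit.

The change on the carbonyl carbon, an at least 1.6-fold lower number from compound 2 to compound 4 (0.20 log units; that floor lies within the scatter), is likewise only a floor, so neither step is shown to go beyond the scatter. Furan-2-yl and 4-nitrophenyl on the carbonyl carbon are not told apart, with a 1.0-fold higher number from compound 3 to compound 4 (0.01 log units; within the scatter), so a number short of the limit is not tied to the 4-nitrophenyl group.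

On these data alone, it stays open whether an amine or a carboxylic acid on the aryl ketone end, or a longer chain in place of the ethenyl link, would move the number beyond the scatter. As far as these compounds go, the true distance of compound 1 and compound 2 from compound 4 also stays open, as their limits give no number.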